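The compounds below may be only part of what the source reports. "The series", "measured", "known", "first", "only" and "open" are said of these compounds alone.

Working notes on the series in a functional assay on HeLa cells (Homo sapiens) for antiproliferative activity, read by MTT assay, with a stated time of 48 h; a higher number here means a weaker inhibitor, a lower number a stronger inhibitor: compound 1 `COc1cccc(-c2nn(-c3ccccc3)cc2C(Nc2nc3ccccc3s2)c2c(O)ccc3ccccc23)c1` gives 14900 nM, compound 2 `COc1ccc(-c2nn(-c3ccccc3)cc2C(Nc2nc3ccccc3s2)c2c(O)ccc3ccccc23)cc1` gives 9340 nM, and compound 3 `Oc1ccc2ccccc2c1C(Nc1nc2ccccc2s1)c1cn(-c2ccccc2)nc1-c1cccc(Cl)c1` gives 6830 nM. The numbers show a 2.2-fold lower number from compound 1 to compound 3 (0.34 log units; beyond the scatter), and a 1.4-fold lower number from compound 2 to compound 3 (0.14 log units; within the scatter), so the third compound separates from only one of the other two.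

Compound 4 `Cc1ccc(-c2nn(-c3ccccc3)cc2C(Nc2nc3ccccc3s2)c2c(O)ccc3ccccc23)cc1` differs from compound 3 at one place: 4-methylphenyl in place of 3-chlorophenyl on an aromatic carbon. This puts 4-methylphenyl in place of 3-chlorophenyl on an aromatic carbon of a five-membered aromatic ring with 2 nitrogen.

All three measured steps vary the substituent at this same place. Besides the two above, the data show a 1.6-fold lower number from compound 1 to compound 2 (0.20 log units; within the scatter), so the steps here are small, and only one passes the scatter. Within the data shown here, no measured compound carries 4-methylphenyl, so the direction is poorly defined. The expected change in this assay is a 1.3-fold higher number from compound 3 to compound 4 (0.12 log units; within the scatter), which means no step beyond the scatter, with a slight lean towards compound 2 at 9340 nM. For compound 4 the estimated value is 9000 nM, with an expected range of 4500 nM to 18000 nM.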

Compound 4, half-maximal inhibitory concentration: 8050 nM
Beside the measured number, compound 4's estimate is 1.1-fold (0.05 log units) above it, within the range that was stated.
By their numbers in this assay, from the lowest: compounds 3, 4, 2 and 1 (each within the scatter of the next, the first and the last beyond it).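

In this assay, 4-methylphenyl on this aromatic carbon of the five-membered aromatic ring with 2 nitrogen gives no step beyond the scatter against any of the three other aryl groups: 3-chlorophenyl (a 1.2-fold higher number from compound 3 to compound 4 (0.07 log units; within the scatter)), 4-methoxyphenyl (a 1.2-fold lower number from compound 2 to compound 4 (0.06 log units; within the scatter)) and 3-methoxyphenyl (a 1.9-fold lower number from compound 1 to compound 4 (0.27 log units; within the scatter)). A methyl group, with no oxygen or chlorine in the entering group, therefore reads alike with all three, and the step from compound 1 to compound 3 remains the only one that passes the scatter. No measurement at hand accounts for this flat reading.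

The substituents shown are limited to chloro, methoxy and methyl, so an amine, a carboxylic acid or a longer chain on this phenyl ring remains open. Also open, as far as these compounds go, is 3-methylphenyl or 4-chlorophenyl, which would separate the substituent from the place it occupies on the phenyl ring.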